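The source may report more compounds than this note shows. Statements on the series, on what has been measured and on what is new or still open speak of the compounds shown alone.

In a physicochemical assay for solubility, in simulated intestinal fluid (a higher number here means a more soluble compound, a lower number a less soluble compound), compound 1 `Cc1nn(CC(=O)N2CCN(c3sc(C(F)(F)F)nc3-c3nc4ccccc4[nH]3)C[C@H]2C)cc1CN(C)C` gives 645 ug/mL. Compound 2 `C[C@@H]1CN(c2sc(C(F)(F)F)nc2-c2nc3ccccc3[nH]2)CCN1C(=O)Cn1cnc2c1CCN(C)C2` reads > 920 ug/mL, which is a limit of the assay and not a number. Compound 3 `C[C@@H]1CN(c2sc(C(F)(F)F)nc2-c2nc3ccccc3[nH]2)CCN1C(=O)Cn1cnc2cccnc21` differs from compound 2 by a group of 9 heavy atoms (6 carbon, 3 nitrogen; one five-membered aromatic ring with 2 hetero atoms, one six-membered aromatic ring with 1 hetero atom) in place of a group of 10 heavy atoms (7 carbon, 3 nitrogen; one five-membered aromatic ring with 2 hetero atoms, one six-membered non-aromatic ring with 1 hetero atom), on a saturated chain carbon bound to a carbonyl carbon. Within the data shown here, the only measured step at that place is an at least 1.4-fold higher number from compound 1 to compound 2 (0.15 log units; that floor lies within the scatter), whose floor lies within the scatter, so it gives little guidance on size. It also brings in no six-membered aromatic ring with 1 hetero atom. Among the measured compounds shown here, with compound 1 at 645 ug/mL as the only true number available, a fall in this assay is expected, though its size is uncertain. The expected change is an at least 7.6-fold lower number from compound 2 to compound 3 (0.88 log units; beyond the scatter). Compound 3 is estimated at 120 ug/mL, with an expected range of 25 ug/mL to 550 ug/mL.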

Compound 3, solubility: 214 ug/mL
The estimate for compound 3 lay 1.8-fold (0.25 log units) below the measured number, and the stated range covers the measured number.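

At this place, on a saturated chain carbon bound to a carbonyl carbon, this assay now shows a change beyond the scatter with true numbers at both ends: a 3.0-fold lower number from compound 1 to compound 3 (0.48 log units; beyond the scatter). The group with a six-membered aromatic ring with 1 hetero atom also gives an at least 4.2-fold lower number from compound 2 to compound 3 (0.63 log units; beyond the scatter). That step is only a floor, and the value of compound 2 is a limit and not a number: the limit of > 920 ug/mL in this assay, at which 1 of the 3 values shown sits.

Going by these compounds, the full size of that step stays open. So does how a carboxylic acid or a hydroxyl group at this place would read.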